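Methyl on the ring: from one core to another

A few compounds are considered here, and "the series" means these few. Any claim that something is new, unique, unknown or untested is made for them only; others in the source may bear on it.

Three related compounds have been tested in a functional assay on A-375 cells (Homo sapiens) for cytotoxicity, read by MTT assay, with a stated time of 72 h, tested at 3 uM; a lower number here means less inhibition of growth, a higher number more inhibition of growth at the concentration tested. Compound 1 `N/C(=N\NC(=S)N1CCCCCC1)c1ccccn1` gives 78.6% and stands highest of the three. Compound 2 `N/C(=N\NC(=S)N1CCOCC1)c1ccccn1` gives 19.3%, and compound 3 `Cc1ccnc(/C(N)=N/NC(=S)N2CCOCC2)c1` gives 66.6%. How the cores of compound 1 and compound 2 differ is not broken down here.

Between compound 2 and compound 3 the change is methyl in place of hydrogen on an aromatic carbon, and the step it made was a number 47.3 percentage points higher from compound 2 to compound 3 (beyond the scatter). Compound 4 `Cc1cccc(/C(N)=N/NC(=S)N2CCCCCC2)n1` is not yet measured; it differs from compound 1 by methyl in place of hydrogen on an aromatic carbon. This is the same kind of change, not the same one: in compound 3 the methyl sits opposite the ring nitrogen, in compound 4 it sits next to the ring nitrogen.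

Among the measured compounds shown here, because compound 1 already gives 78.6%, little room remains upward, so the step expected here is far smaller than the one seen from compound 2 to compound 3. The expected step is about a number 5.4 percentage points higher from compound 1 to compound 4 (within the scatter). Compound 4 is therefore estimated at 84%, roughly between 66% and 95%.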

Compound 4, percent growth inhibition at one concentration: 64.5%
Compound 4: the middle estimate sits 19.5 percentage points above what was measured; the whole stated range lies above it.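

In this assay, methyl in place of hydrogen on an aromatic carbon did not carry over from one core to the other, and the two steps point in opposite directions: the same change on two cores in this assay, a number 47.3 percentage points higher (beyond the scatter) from compound 2 to compound 3 and a number 14.1 percentage points lower (beyond the scatter) from compound 1 to compound 4, 61.4 percentage points apart, beyond the scatter of two such steps. The new step is a number 14.1 percentage points lower from compound 1 to compound 4 (beyond the scatter): on the core of compound 1, a methyl next to the ring nitrogen comes with less inhibition of growth, not more. With only these two pairs, the effect of the core cannot be separated from the effect of the methyl's place on the ring, which differs between compound 3 and compound 4.

The compounds shown leave open whether a methyl at the same place on both cores would give matching steps. From the compounds shown here alone, an ethyl, a methoxy or an amine on the ring is not among them, and what any of these would do to growth inhibition on either core remains unknown.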